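The source may report more compounds than this note shows. Statements on the series, on what has been measured and on what is new or still open speak of the compounds shown alone.

Measured compounds:
compound 1 `CCCn1c(=O)c2nc(C(O)(CC)CC)[nH]c2n(CCC)c1=O` — 170 nM
compound 2 `CCCn1c(=O)c2nc(C(C)(O)CC)[nH]c2n(CCC)c1=O` — 240 nM

In an assay on cell membranes for binding affinity to adenosine receptor A1 (Cavia porcellus), read by radioligand binding (a higher number here means a weaker inhibitor, a lower number a stronger inhibitor), compound 1 gives 170 nM and compound 2 gives 240 nM; the step of a 1.4-fold higher number from compound 1 to compound 2 (0.15 log units; within the scatter) leaves the two indistinguishable, so compound 1 stands level with compound 2 on these numbers. Compound 3 `CCCn1c(=O)c2nc(CC(C)(C)C)[nH]c2n(CCC)c1=O` carries neopentyl in place of 1-ethyl-1-hydroxypropyl on an aromatic carbon. Within the data shown here, the one measured step, from compound 1 to compound 2, touched a saturated chain carbon and kept the hydroxyl, whereas here the hydroxyl leaves altogether. Among the measured compounds shown here, no measured step covers that loss, so the expected shift in this assay is a 1.8-fold higher number from compound 1 to compound 3 (0.25 log units; within the scatter), with the direction uncertain. Compound 3 is therefore estimated at 300 nM, with a range from 100 nM to 1000 nM.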

Compound 3, inhibition constant: 49 nM
For compound 3 the middle estimate is 6.1-fold (0.79 log units) above the measured one; measured number below the stated range.
By their numbers in this assay, from the lowest: compound 3; then compounds 1 and 2 (each within the scatter of the next).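

In this assay, neopentyl in place of 1-ethyl-1-hydroxypropyl gives a 3.5-fold lower number from compound 1 to compound 3 (0.54 log units; beyond the scatter), and neopentyl in place of 1-hydroxy-1-methylpropyl gives a 4.9-fold lower number from compound 2 to compound 3 (0.69 log units; beyond the scatter), so changes at this position can move the number beyond the scatter. A hydroxyl on this group is thus not needed for the lowest number shown. Nothing available accounts for this shift. The compounds shown leave open whether the hydroxyl's loss or the altered carbon chain drives the shift, and how an amine in the hydroxyl's place or a longer chain would read here.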